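The source may hold more compounds than are shown below. What is called first, only, known or untested is meant among the compounds shown, and "the series" means these compounds.

In an ADME assay on microsomes from liver (Mus musculus) for metabolic stability, with a stated time of 10 min (a higher number here means that more of the compound is left, a lower number that less of the compound is left), three compounds that share a core have been measured. Compound 1 `CC(=O)N1CC[C@@H](C(=O)N2CC[C@](c3ccc(C(OCc4c(F)cccc4F)(C(F)(F)F)C(F)(F)F)cc3)(S(=O)(=O)c3ccc(F)cc3)C2)C1` gives 55%, compound 2 `CC(=O)N1CCN(C(=O)N2CC[C@](c3ccc(C(OCc4c(F)cccc4F)(C(F)(F)F)C(F)(F)F)cc3)(S(=O)(=O)c3ccc(F)cc3)C2)CC1` gives 59% and compound 3 `Cc1cccc(C)c1COC(c1ccc([C@]2(S(=O)(=O)c3ccc(F)cc3)CCN(C(=O)[C@H]3CC[C@H](C(=O)O)CC3)C2)cc1)(C(F)(F)F)C(F)(F)F` gives 77%. Compound 3 therefore has the highest of the three numbers, and its gaps to both of the others lie beyond the usual scatter.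

The next structure, compound 4 `O=C(O)[C@H]1CC[C@H](C(=O)N2CC[C@](c3ccc(C(OCC4CC4)(C(F)(F)F)C(F)(F)F)cc3)(S(=O)(=O)c3ccc(F)cc3)C2)CC1`, differs from compound 3 at a single place: cyclopropyl in place of 2,6-dimethylphenyl on a saturated chain carbon bound to an oxygen on a saturated carbon. Cut one bond further out, the same difference reads 2,6-dimethylbenzyl to cyclopropylmethyl.

For the measured compounds named here, only one measured step is available, a number 4 percentage points higher from compound 1 to compound 2 (within the scatter). It lies at another place, with 4-acetylpiperazin-1-yl in place of 1-acetylpyrrolidin-3-yl on a carbonyl carbon, so it does not bear directly on this change. Going by the values given here, no measured pair isolates the group that leaves, and the data give no direction for the change. The best anchor is compound 3 itself, at 77%, so no shift beyond the scatter is expected in this assay, though the uncertainty remains wide. The expected change is a number 1 percentage points higher from compound 3 to compound 4 (within the scatter). For compound 4 the estimated value is 78%, with an expected range from 58% to 92%.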

Compound 4, percent of the compound remaining: 44%
Compound 4: middle estimate off by 34 percentage points, on the high side; the whole stated range lies above it.
By their numbers in this assay, from the lowest: compound 4; then compounds 1 and 2 (each within the scatter of the next); then compound 3.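

In this assay the group on the saturated chain carbon bound to an oxygen proves to matter: cyclopropyl in place of 2,6-dimethylphenyl gives a number 33 percentage points lower from compound 3 to compound 4 (beyond the scatter), a large step. For the compounds shown here, the earlier compounds offered only a change at another place, the acyl group on the carbonyl carbon, where the step was a number 4 percentage points higher from compound 1 to compound 2 (within the scatter), so this pair is the first to show that the read-out responds strongly to a single change in the shared core's substituents, here with the carboxylic acid side held constant. No measurement at hand accounts for the drop.

This single pair changes several things at once, from a six-membered aromatic ring to a three-membered non-aromatic ring and from 8 heavy atoms to 3, so the compounds shown leave open which of these differences goes with the lower number. Groups such as unsubstituted benzyl or cyclohexylmethyl at this place would be needed to separate them, and the 2,6-difluorobenzyl group of compounds 1 and 2 stands on a different acyl group, so it gives no direct comparison with compound 3 or compound 4.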